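Compound 2 and the Sulfoethyl Exchange

This account rests on a few compounds, and the source may have more. Where it says the series, first, only, none or still open, it means among the compounds named here.

In a functional assay on MCF7 cells (Homo sapiens) for inhibition, read by MTT assay, with a stated time of 3 days (a higher number here means a weaker inhibitor, a lower number a stronger inhibitor), compound 1 `CCOC(=O)[C@@H](NCC(=O)NNC(=O)COc1ccc(-c2nc3ccccc3s2)cc1OC)[C@@H](C)CC` gives 1950 nM and compound 2 `CCOC(=O)[C@H](NCC(=O)NNC(=O)COc1ccc(-c2nc3ccccc3s2)cc1OC)[C@@H](C)CC` gives 2900 nM. The two numbers lie within the scatter of each other, so compound 2 stands level with compound 1 on the only data so far. Going by the values given here, the single measured step, a 1.5-fold higher number from compound 1 to compound 2 (0.17 log units; within the scatter), comes with the fact that compounds 1 and 2 differ only in the configuration as drawn. It therefore speaks to configuration alone.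

Compound 3 `CCOC(=O)[C@H](CS(=O)(=O)O)NCC(=O)NNC(=O)COc1ccc(-c2nc3ccccc3s2)cc1OC` keeps the shared core but carries 1-(ethoxycarbonyl)-2-sulfoethyl in place of 1-(ethoxycarbonyl)-2-methylbutyl on an amine nitrogen. Among the compounds with values here, no measured step covers an exchange of this kind, so the small step between compound 1 and compound 2 sets no size for it. The change is much larger than a switch of configuration, and a shift in this assay beyond the scatter is possible, though the data fix neither its size nor its direction. A modest move towards a higher number is the tentative expectation, stated as the expected step of a 1.7-fold higher number from compound 2 to compound 3 (0.24 log units; within the scatter). For compound 3 the estimated value is 5000 nM, within an expected range of 1500 nM to 20000 nM.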

Compound 3, half-maximal inhibitory concentration: 1990 nM
Beside the measured number, compound 3's estimate is 2.5-fold (0.40 log units) above it; measured number inside the range.
By their numbers in this assay, from the lowest: compounds 1, 3 and 2 (each within the scatter of the next).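

At this place, on an amine nitrogen, 1-(ethoxycarbonyl)-2-sulfoethyl in place of 1-(ethoxycarbonyl)-2-methylbutyl gives, in this assay, a 1.5-fold lower number from compound 2 to compound 3 (0.16 log units; within the scatter) and so moves the number no further than the scatter. The same holds when the exchange is read as sulfomethyl in place of sec-butyl on a saturated chain carbon bound to an amine nitrogen and a carbonyl carbon, which gives a 1.0-fold higher number from compound 1 to compound 3 (0.01 log units; within the scatter) in this assay. The earlier compounds tested only a switch of configuration at this part of the molecule, whereas here the group itself changes, with sulfur and more oxygen entering, and the three numbers remain level, though no available evidence offers a reason for this.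

The compounds shown leave open whether a carboxylic acid or an amine in the place of the sulfo group, or a longer chain carrying the sulfo group, would also stay within the scatter. Also open, going by these compounds, is whether the opposite configuration at the chain carbon of compound 3 would stay level with it, and whether the ethyl ester matters to the number.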